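From pyridin-3-yl to cyclohexyl on an amide-type nitrogen

A few compounds are considered here, and "the series" means these few. Any claim that something is new, unique, unknown or untested is made for them only; others in the source may bear on it.

In a functional assay on HeLa cells (Homo sapiens) for inhibition, read by MTT assay, with a stated time of 72 h (a higher number here means a weaker inhibitor, a lower number a stronger inhibitor), compound 1 (`O=C(Nc1ccc(Oc2ncnc3[nH]ncc23)cc1)Nc1ccc(C(F)(F)F)cc1`) gives > 10000 nM as a limit of the assay and not a number. Compound 2 (`O=C(Nc1ccc(Oc2ncnc3[nH]ncc23)cc1)Nc1cccnc1`) gives > 10000 nM which is also only a limit. Both compounds therefore sit at the same limit (the limit of > 10000 nM in this assay, at which 2 of the 2 values shown sit) and compound 2 has no numerical value. Within the data shown here, the one measured step that bears on the change is a step that the two limits leave unreadable from compound 1 to compound 2 and it offers no size to carry forward.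

Compound 3 (`O=C(Nc1ccc(Oc2ncnc3[nH]ncc23)cc1)NC1CCCCC1`) has cyclohexyl in place of pyridin-3-yl on an amide-type nitrogen on the shared core.

With compound 2 at > 10000 nM as a limit, no step beyond the scatter is expected in this assay and compound 3 will probably stay at the limit too. The expected step is a step that the limit leaves unreadable from compound 2 to compound 3 as a rough working figure. For compound 3 the estimate is 14000 nM with an expected range from 6000 nM to 30000 nM in this assay.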

Compound 3, half-maximal inhibitory concentration: > 10000 nM
Compound 3: a limit, no number; the forecaster's own chance of this, stated with the estimate: 75%; the middle value is on the limit's open side.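

In this assay compound 3 gives > 10000 nM, which is a limit and not a number. No step among compound 1, compound 2 and compound 3 can be read: the limit of > 10000 nM in this assay, at which 3 of the 3 values shown sit.

The compounds shown leave open whether any group on the amide-type nitrogen gives a numerical value in this assay.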